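Hydrazone aryl swap on the triazolyl pyridine ether series

This account rests on a few compounds, and the source may have more. Where it says the series, first, only, none or still open, it means among the compounds named here.

Measured in a functional assay on NCI-H460 cells (Homo sapiens) for cytotoxicity, read by MTT assay, with a stated time of 72 h; a higher number here means a weaker inhibitor, a lower number a stronger inhibitor:
compound 1 `CN(C)CCn1cnnc1-c1cc(Oc2ccc(NC(=O)N/N=C/c3ccc(Cl)cc3)cc2F)ccn1`: 320 nM
compound 2 `CN(C)CCn1cnnc1-c1cc(Oc2ccc(NC(=O)N/N=C/c3cc(Br)c(O)c(Br)c3)cc2F)ccn1`: 3760 nM
compound 3 `Cn1cnnc1-c1cc(Oc2ccc(NC(=O)N/N=C/c3ccccc3)cc2F)ccn1`: 15700 nM

Compound 2 stands second highest of the three numbers in this assay; its nearest neighbour is compound 3, its furthest compound 1. Compound 3 also lacks the dimethylaminoethyl chain carried by compound 1 and compound 2, so its value shows two changes at once and is not a clean comparison.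

The next compound, compound 4 `COc1cc(/C=N/NC(=O)Nc2ccc(Oc3ccnc(-c4nncn4CCN(C)C)c3)c(F)c2)cc(OC)c1OC`, differs from compound 2 by 3,4,5-trimethoxyphenyl in place of 3,5-dibromo-4-hydroxyphenyl on a carbon with a double bond to nitrogen.

Among the measured compounds shown here, only one measured step touches this position: a 12-fold higher number from compound 1 to compound 2 (1.07 log units; beyond the scatter). That step shows the aryl group on the hydrazone carbon can move the number a long way, but nothing measured shows what 3,4,5-trimethoxyphenyl does there. Since compound 2 itself sits on the weak side of that large step, a return toward the value of compound 1 is plausible, and the expected step of a 2.5-fold lower number from compound 2 to compound 4 (0.40 log units; beyond the scatter) in this assay is therefore taken as a moderate drop in the number, held with a wide range. For compound 4 the estimate in this assay is 1500 nM, between 300 nM and 8000 nM.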

Compound 4, half-maximal inhibitory concentration: 2770 nM
Compound 4: middle estimate off by 1.8-fold (0.27 log units), on the low side, within the range that was stated.
By their numbers in this assay, from the lowest: compound 1; then compounds 4 and 2 (each within the scatter of the next); then compound 3.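

In this assay, replacing 3,5-dibromo-4-hydroxyphenyl with 3,4,5-trimethoxyphenyl on the carbon with a double bond to nitrogen gives a 1.4-fold lower number from compound 2 to compound 4 (0.13 log units; within the scatter), so these two groups cannot be told apart here despite their different counts of heavy atoms, hydrogen-bond donors and hydrogen-bond acceptors. The same entering group measured against 4-chlorophenyl gives an 8.7-fold higher number from compound 1 to compound 4 (0.94 log units; beyond the scatter), in the same direction as a 12-fold higher number from compound 1 to compound 2 (1.07 log units; beyond the scatter), which means the weak reading of compound 2 is no longer a result of the dibromo-hydroxy group alone: among the three aryl groups on the dimethylaminoethyl series, compound 1 stands apart and compounds 2 and 4 read alike. No measurement at hand accounts for either the similarity or the gap.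

Still open, as far as these compounds go, is whether the reading of compound 1 depends on the chlorine itself or on the ring carrying only one substituent, and a plain phenyl group with the dimethylaminoethyl chain, which compound 3 cannot stand in for, would help to separate these. It is also open how an aminophenyl or a carboxyphenyl group would read on this carbon, as the compounds shown carry neither an amine nor a carboxylic acid on this ring.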